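An Isopropyl Group on the Amide Nitrogen

The compounds below may be only part of what the source reports. "The series", "measured", "known", "first", "only" and "open" are said of these compounds alone.

Compound 1, `NC(=O)c1cc(-c2cccc(OC(=O)NC3CCCCC3)c2)n(-c2ccccc2)n1`, gives 169 nM in an assay on isolated protein for inhibition of Fatty-acid amide hydrolase 1 (Homo sapiens), read by fluorescence, with a stated time of 30 min; on this read-out lower numbers stand for stronger inhibition and higher numbers for weaker inhibition.
Compound 2, `NC(=O)c1cc(-c2cccc(OC(=O)NC3CCCCC3)c2)n(-c2ccc(Cl)cc2)n1`, gives 174 nM in this assay.

Compound 1 holds the lower of the two numbers, though the gap to compound 2 lies within the scatter: a 1.0-fold higher number from compound 1 to compound 2 (0.01 log units; within the scatter). Compound 3, `CC(C)NC(=O)c1cc(-c2cccc(OC(=O)NC3CCCCC3)c2)n(-c2ccccc2)n1`, differs from compound 1 by isopropyl in place of hydrogen on an amide-type nitrogen. Going by the values given here, no measured step bears on this change. The single step shown, from compound 1 to compound 2, concerns a substituent on an aromatic carbon and left the number essentially where it was, so it gives no guide to what an alkyl group on the amide nitrogen will do. With nothing to rest on, a moderate weakening is taken as the working expectation, and the estimated step is a 2.4-fold higher number from compound 1 to compound 3 (0.37 log units; beyond the scatter). Compound 3 is therefore expected to give about 400 nM in this assay, with an estimated range from 100 nM to 1600 nM.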

Compound 3, half-maximal inhibitory concentration: 232 nM
Compound 3: middle estimate off by 1.7-fold (0.24 log units), on the high side; the range from low to high includes it.
By their numbers in this assay, from the lowest: compounds 1, 2 and 3 (each within the scatter of the next).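

Compound 1 and compound 3 cannot be told apart in this assay, where the change gives a 1.4-fold higher number from compound 1 to compound 3 (0.14 log units; within the scatter). Going by these compounds alone, the earlier step concerned only a chloro group on an aromatic carbon, so this is the first sign that the amide-type nitrogen can also carry a substituent, here isopropyl with its 3 carbons, without a step beyond the scatter. No independent measurement bears on why the number behaves this way at this position.

The compounds shown leave open whether this nitrogen would accept a longer chain or a group carrying an amine or a carboxylic acid in the same way. They also leave open whether isopropyl on this nitrogen would give a similar result when combined with the chloro group of compound 2.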